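The source may hold more compounds than are shown below. What is called first, only, known or untested is meant among the compounds shown, and "the series" means these compounds.

Working notes on the series. Compound 1 `Cc1ccc(C(=O)Nc2cccc(-c3oc4cc(-c5ccc(F)cc5)ccc4c(=O)c3O)c2)cc1` and compound 2 `COc1cccc(C(=O)Nc2cccc(-c3oc4cc(-c5ccc(F)cc5)ccc4c(=O)c3O)c2)c1` share one core and differ only in the group on the carbonyl carbon of the amide. In a functional assay on MCF7 cells (Homo sapiens) for antiproliferative activity, read by CCK-8 assay, with a stated time of 72 h (a higher number here means a weaker inhibitor, a lower number a stronger inhibitor), compound 1 gives 2400 nM, while compound 2 gives 15300 nM; the step between them is a 6.4-fold higher number from compound 1 to compound 2 (0.80 log units; beyond the scatter). Among the two numbers in hand, compound 1 thus stands lowest.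

Compound 3 `O=C(Nc1cccc(-c2oc3cc(-c4ccc(F)cc4)ccc3c(=O)c2O)c1)c1ccc(Cl)nc1` is not yet measured. Against compound 1 the change is 6-chloropyridin-3-yl in place of 4-methylphenyl on a carbonyl carbon. Within the data shown here, the only measured step that bears on it is the one at the same carbonyl carbon, a 6.4-fold higher number from compound 1 to compound 2 (0.80 log units; beyond the scatter), which was modest and upward; no measured step involves a 6-chloropyridin-3-yl group. By that precedent a further departure from 4-methylphenyl is expected to raise the number in this assay, by a step of a 2.5-fold higher number from compound 1 to compound 3 (0.40 log units; beyond the scatter). Compound 3 is therefore estimated at 6000 nM, with a range from 2000 nM to 20000 nM.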

Compound 3, half-maximal inhibitory concentration: 2890 nM
Estimate against measurement, compound 3: 2.1-fold (0.32 log units) above; measured number inside the range.
By their numbers in this assay, from the lowest: compounds 1 and 3 (each within the scatter of the next); then compound 2.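

In this assay the step of a 1.2-fold higher number from compound 1 to compound 3 (0.08 log units; within the scatter) shows that this carbonyl carbon can carry 6-chloropyridin-3-yl in place of 4-methylphenyl without a difference beyond the scatter, so the earlier rise does not apply to every departure from 4-methylphenyl. Among these compounds, the step of a 5.3-fold lower number from compound 2 to compound 3 (0.72 log units; beyond the scatter) leaves 3-methoxyphenyl as the one group of the three set apart from the others in this assay. No measurement available here gives a reason for this difference between the groups.

Still open, from the compounds shown here alone, is whether a plain phenyl, or a pyridine ring without the chlorine, would stay level with compound 1 and compound 3. Also open, going by these compounds, is how a ring bearing an amine or a carboxylic acid, or a longer chain in place of the ring, would read at this carbonyl carbon.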